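A few compounds are considered here, and "the series" means these few. Any claim that something is new, unique, unknown or untested is made for them only; others in the source may bear on it.

Measured so far:
- compound 1, `O=c1c(-c2ccc(O)cc2)coc2cc(OCCCCCCCCCO)ccc12` — 700 nM
- compound 2, `O=C(O)CCCCCOc1ccc2c(=O)cc(-c3ccc(O)cc3)oc2c1` — 3500 nM
- compound 3, `O=C(O)CCCCCCCCCCCCCCCOc1ccc2c(=O)c(-c3ccc(O)cc3)coc2c1` — > 9000 nM, a limit of the assay rather than a number

In an assay (Cricetulus griseus) for inhibition of aldehyde dehydrogenase, mitochondrial (Homo sapiens) (on this read-out higher numbers stand for weaker inhibition and lower numbers for stronger inhibition), compound 1 gives 700 nM, the lowest of the two numbers recorded. Compound 2 gives 3500 nM, a higher number. For compound 3 the assay reports only a limit, > 9000 nM, and no number.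

Compound 4, `O=C(O)COc1ccc2c(=O)c(-c3ccc(O)cc3)coc2c1`, has not yet been measured. It differs from compound 1 in one place: carboxy in place of 8-hydroxyoctyl on a saturated chain carbon bound to an oxygen on an aromatic ring. Going by the values given here, the one measured step that bears on this is an at least 12-fold higher number from compound 1 to compound 3 (1.10 log units; beyond the scatter), which also exchanged the hydroxy group of compound 1 for an acid-bearing chain and ended at the limit of > 9000 nM in this assay, at which 1 of the 3 values shown sits. Compound 2, an acid on a shorter chain though on a different core, also sits at a higher number than compound 1. A higher number, meaning weaker inhibition, is therefore expected for compound 4, a step of about a 5.7-fold higher number from compound 1 to compound 4 (0.76 log units; beyond the scatter) in this assay. The estimate for compound 4 is 4000 nM, with a range from 1000 nM to 15000 nM.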

Compound 4, half-maximal inhibitory concentration: 1200 nM
Estimate against measurement, compound 4: 3.3-fold (0.52 log units) above, and the stated range covers the measured number.
By their numbers in this assay, from the lowest: compounds 1 and 4 (each within the scatter of the next); then compound 2. At a limit, above all of these: compound 3.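

In this assay, carboxy in place of 8-hydroxyoctyl, on a saturated chain carbon bound to an oxygen on an aromatic ring, gives a 1.7-fold higher number from compound 1 to compound 4 (0.23 log units; within the scatter), so the two compounds cannot be told apart here. This position therefore tolerates an acid, and the long chain ending in hydroxy is not needed to keep the number in this range. Compound 3, which holds its acid on a far longer chain, reaches only a limit and no number, so the acid group alone cannot account for that result: the limit of > 9000 nM in this assay, at which 1 of the 4 values shown sits.

From the compounds shown here alone, it remains open how an acid on a chain of middle length behaves on this same core, and at what length the number starts to rise. Going by these compounds, it is also open whether an amine or a methyl ester at this position would fit as well as carboxy.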